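The source may report more compounds than this note shows. Statements on the series, on what has been measured and on what is new or still open speak of the compounds shown alone.

Compound 1, `C=C[C@@](C)(/C=C/c1ccc(O)c(/C=C/C(=O)OCC)c1)CCC=C(C)C`, in a functional assay on HepG2 cells (Homo sapiens) for cytotoxicity, with a stated time of 72 h (a higher number here means that more compound is needed for the effect, a lower number that less compound is needed), gives > 52000 nM, which is a limit of the assay rather than a number.
Compound 2, `C=C[C@@](C)(/C=C/c1ccc(O)c(/C=C/C(=O)OCc2ccccc2)c1)CCC=C(C)C`, in this assay gives > 52000 nM, again a limit.
Compound 3, `C=C[C@@](C)(/C=C/c1ccc(O)c(/C=C/C(N)=O)c1)CCC=C(C)C`, in this assay gives > 52000 nM, also a limit.

All three measured compounds share one core and differ only in the group on the carbonyl carbon of the side chain. None of them gives a number: each sits at the limit of > 52000 nM in this assay, at which 3 of the 3 values shown sit, so no cytotoxic effect was reached within the tested range. Compound 3 therefore stands at the same limit as the other two, neither more nor less potent than them on the evidence shown.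

Compound 4, `C=C[C@@](C)(/C=C/c1ccc(O)c(/C=C/c2ccc(Cl)c(Cl)c2)c1)CCC=C(C)C`, goes further. Its difference from compound 3 is 3,4-dichlorophenyl in place of carbamoyl on a double-bonded chain carbon bound to a double-bonded chain carbon. The carbonyl group that carried the ethoxy, benzyloxy or amino group in the measured compounds is gone altogether, and an aromatic ring takes its place.

The measured steps that touch this part of the molecule are a step that the two limits leave unreadable from compound 1 to compound 3 and a step that the two limits leave unreadable from compound 2 to compound 3, and both are unreadable, since each starts and ends at a limit. They give no size and no direction for the change to compound 4. Replacing the carbamoyl group by a 3,4-dichlorophenyl group is a larger structural move than any of the measured steps, so the three measured compounds do not bound what compound 4 may do.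

With nothing measured to lean on, compound 4 is expected to give roughly 40000 nM in this assay, somewhere between 8000 nM and 150000 nM. That expectation corresponds to a step of an at least 1.3-fold lower number from compound 3 to compound 4 (0.11 log units; that floor lies within the scatter), and it is held loosely.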

Compound 4, half-maximal effective concentration: > 52000 nM
Compound 4: no number, only a limit (the forecaster's own chance of this, stated with the estimate: 55%); middle value at least 1.3-fold (0.11 log units) away from the limit.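

Compound 4 also stops at a limit rather than a number, so its steps from compound 1, compound 2 and compound 3 cannot be read in size or direction. All four compounds end the same way: the limit of > 52000 nM in this assay, at which 4 of the 4 values shown sit. The compounds shown leave open at what concentration, if any, each would reach the effect in this assay, and so whether the group on the side chain matters.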